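A nitro group joins the shared core

The source may report more compounds than this note shows. Statements on the series, on what has been measured and on what is new or still open speak of the compounds shown alone.

Compound 1 `N#Cc1ccccc1-c1nc2cccnc2o1`: 61%
Compound 2 `c1ccc(-c2nc3cccnc3o2)cc1`: 55%
Compound 3 `COc1ccc(-c2nc3cccnc3o2)cc1`: 29%

In a functional assay on the whole organism for inhibition, with Rattus norvegicus as the target, at a dose of 30 mg/kg (a lower number here means less inhibition, a higher number more inhibition at the dose given (going by the name of the read-out)), compound 2 stands second highest of the three numbers. One measured step lies within the scatter, a number 6 percentage points lower from compound 1 to compound 2 (within the scatter), and the other beyond it, a number 26 percentage points lower from compound 2 to compound 3 (beyond the scatter). Compound 4 `O=[N+]([O-])c1ccccc1-c1nc2cccnc2o1` differs from compound 2 by nitro in place of hydrogen on an aromatic carbon. Both measured steps bear on this change, since each swaps hydrogen for a small group on an aromatic carbon: the cyano step was small, the methoxy step modest. A nitro group is neither, so the outcome is uncertain, and no change beyond the scatter is expected. The expected step is a number 2 percentage points higher from compound 2 to compound 4 (within the scatter). Compound 4 is estimated at 57%, between 35% and 78%.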

Compound 4, a percentage reported as inhibition, in the whole organism at one dose (the size of the read-out at that dose, not a potency): 57%
The estimate for compound 4 equals the measured number at the digits printed, and the stated range covers the measured number.
By their numbers in this assay, from the lowest: compound 3; then compounds 2, 4 and 1 (each within the scatter of the next).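

Read in this assay, hydrogen to nitro is a number 2 percentage points higher from compound 2 to compound 4 (within the scatter) and cyano to nitro is a number 4 percentage points lower from compound 1 to compound 4 (within the scatter) on the same aromatic carbon, ortho to a group of 9 heavy atoms. So nitro and cyano at this place both stay within the scatter of hydrogen, and of each other, which the earlier compounds could not show for a second group. No measurement here offers a reason for this. From the compounds shown here alone, whether an amine or a carboxylic acid on this carbon would also stay within the scatter remains open.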